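The compounds below may be only part of what the source reports. "The series", "measured", "known", "first", "only" and "open" are said of these compounds alone.

Notes on the series in a functional assay on A20 cells (Mus musculus) for inhibition, with stated times of 1 h, 16 h and 24 h (on this read-out lower numbers stand for stronger inhibition and higher numbers for weaker inhibition), follow. Within the data shown here, compound 3 (`N#CC1(NC(=O)[C@@H]2C[C@@H](S(=O)(=O)c3ccccc3)C[C@H]2C(=O)N2CC3(COC3)C2)CC1`) stands at 248 nM on this read-out, the middle of the three numbers so far. Compound 1 (`N#CCNC(=O)[C@@H]1C[C@@H](S(=O)(=O)CC2CC2)C[C@H]1C(=O)N1CCOCC1`) has the higher number (4510 nM) and compound 2 (`N#CC1(NC(=O)[C@@H]2C[C@@H](S(=O)(=O)c3ccccc3)C[C@H]2C(=O)N2CCOCC2)CC1`) the lower (12 nM). Among the measured compounds shown here, compound 1 differs from compound 3 in more than one place, so it offers no clean step here.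

The next compound is compound 4 (`N#CC1(NC(=O)[C@@H]2C[C@@H](S(=O)(=O)c3ccccc3)C[C@H]2C(=O)N2CCNCC2)CC1`), which keeps the rest of compound 3 and changes only the group on a carbonyl carbon: a group of 6 heavy atoms (4 carbon, 2 nitrogen; one six-membered non-aromatic ring with 2 hetero atoms) in place of a group of 7 heavy atoms (5 carbon, 1 nitrogen, 1 oxygen; 2 four-membered non-aromatic rings with 1 hetero atom each), on a carbonyl carbon. For the measured compounds named here, the one measured step at this carbonyl carbon is a 21-fold higher number from compound 2 to compound 3 (1.32 log units; beyond the scatter), where a six-membered non-aromatic ring with 2 hetero atoms gave way to the group with 2 four-membered non-aromatic rings. The piperazin-1-yl group restores a six-membered ring with 2 hetero atoms, but with nitrogen where compound 2 (12 nM) has oxygen. Going by the values given here, no measurement yet isolates that exchange, so only part of the earlier step may be recovered.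

A large step toward a lower number is therefore expected, estimated as an 8.3-fold lower number from compound 3 to compound 4 (0.92 log units; beyond the scatter) in this assay. Compound 4 is expected at 30 nM, with an estimated range from 8 nM to 120 nM on this read-out.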

Compound 4, half-maximal inhibitory concentration: 1340 nM
Compound 4: the middle estimate sits 45-fold (1.65 log units) below what was measured, and the stated range ends below it.
By their numbers in this assay, from the lowest: compound 2; then compound 3; then compound 4; then compound 1.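

In this assay, among these compounds, the exchange of morpholin-4-yl for piperazin-1-yl on a carbonyl carbon can now be read on its own, and it gives a 110-fold higher number from compound 2 to compound 4 (2.05 log units; beyond the scatter) as the largest step so far, so a six-membered non-aromatic ring with 2 hetero atoms does not by itself keep the low number of compound 2. The group with 2 four-membered non-aromatic rings, already costly in a 21-fold higher number from compound 2 to compound 3 (1.32 log units; beyond the scatter) as a change from morpholin-4-yl, still stands ahead of piperazin-1-yl, as a 5.4-fold higher number from compound 3 to compound 4 (0.73 log units; beyond the scatter) shows, which gives the order morpholin-4-yl, then that group, then piperazin-1-yl among these three compounds. Nothing at hand explains why ring nitrogen with its hydrogen-bond donor and ring oxygen part so widely at this position.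

Open, from the compounds shown here alone, is whether the loss follows the hydrogen on the ring nitrogen, which a methyl or acetyl group on that nitrogen of the piperazine would test against compound 4. Also open, going by these compounds, is whether this order at the carbonyl carbon holds with a cyclopropylmethyl group in place of the phenyl on the sulfonyl, since compound 1 differs from the others in more than one place.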